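A Larger Amide on the Piperidine Carboxamide Core

The compounds below may be only part of what the source reports. "The series", "measured", "known", "first", "only" and "open" are said of these compounds alone.

Compound 1 `CCN(CC)S(=O)(=O)c1ccc(S(=O)(=O)N2CCC[C@@H](C(=O)N(C)C(C)C)C2)cc1` was tested in a functional assay on MIA PaCa-2 cells (Homo sapiens) for inhibition, read by MTT assay, with a stated time of 7 days (on this read-out lower numbers stand for stronger inhibition and higher numbers for weaker inhibition), where compound 1 gives 6200 nM, the highest of the three numbers in hand. Compound 2 `CCOC(=O)[C@@H]1CCCN(S(=O)(=O)c2ccc(S(=O)(=O)N(CC)CC)cn2)C1` gives 1300 nM in this assay, and compound 3 `CC(C)c1noc(N2CCN(C(=O)[C@@H]3CCCN(S(=O)(=O)c4ccc(S(=O)(=O)NC5CC5)cc4)C3)CC2)n1` gives 1000 nM; both of these gaps from compound 1 lie beyond the scatter. Compound 4 `CCN(CC)S(=O)(=O)c1ccc(S(=O)(=O)N2CCC[C@@H](C(=O)N3CCN(c4nc(C)no4)CC3)C2)cc1` has not yet been measured. It differs from compound 1 in one place: 4-(3-methyl-1,2,4-oxadiazol-5-yl)piperazin-1-yl in place of isopropyl(methyl)amino on a carbonyl carbon. Compound 3 also carries a piperazinyl oxadiazole amide and gives 1000 nM, which suggests such a group is tolerated on this core. One would therefore expect a step towards a lower number, a 4.1-fold lower number from compound 1 to compound 4 (0.62 log units; beyond the scatter), beyond the scatter. Compound 4 is estimated at 1500 nM, with a range from 500 nM to 5000 nM.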

Compound 4, half-maximal inhibitory concentration: 250 nM
Estimate against measurement, compound 4: 6.0-fold (0.78 log units) above; the whole stated range lies above it.
By their numbers in this assay, from the lowest: compound 4; then compounds 3 and 2 (each within the scatter of the next); then compound 1.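

In this assay, 4-(3-methyl-1,2,4-oxadiazol-5-yl)piperazin-1-yl in place of isopropyl(methyl)amino on the carbonyl carbon gives a 25-fold lower number from compound 1 to compound 4 (1.39 log units; beyond the scatter) as a large change at this single position. The earlier compounds shown here differ from one another in more than one place, so they could not separate the effect of this amide from other changes. No measurement shown here accounts for the size of the step.

The compounds shown leave open whether the oxadiazole is needed, since none carries a piperazine with a free amine at that end. They also leave open how a carboxylic acid on the piperazine would compare.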